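Replacing tert-butyl with piperazin-1-yl on the shared core

A few compounds are considered here, and "the series" means these few. Any claim that something is new, unique, unknown or untested is made for them only; others in the source may bear on it.

In a functional assay on C6 cells (Rattus norvegicus) for inhibition, read by sulforhodamine B assay, with a stated time of 72 h (a lower number here means that less compound is needed, a higher number that more compound is needed for the effect), compound 2 (`CC(C)(C)c1ccc(C(=O)/C=C/c2ccc([N+](=O)[O-])o2)cc1`) gives 28600 nM. Compound 3 (`O=C(/C=C/c1ccc([N+](=O)[O-])o1)c1ccc(N2CCCC2)cc1`) gives 16400 nM, and a 1.7-fold lower number from compound 2 to compound 3 (0.24 log units; within the scatter) stays within the scatter, so these two share the upper end of the three numbers. Compound 1 (`O=C(/C=C/c1ccc([N+](=O)[O-])o1)c1ccc(I)cc1`) gives 2100 nM, clearly apart from both.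

The change now in question leads to compound 4 (`O=C(/C=C/c1ccc([N+](=O)[O-])o1)c1ccc(N2CCNCC2)cc1`), with piperazin-1-yl in place of tert-butyl on an aromatic carbon, para to a large group: piperazin-1-yl in place of tert-butyl on an aromatic carbon. Among the measured compounds shown here, the closest precedent is the step to compound 3, where pyrrolidin-1-yl takes the place of tert-butyl at the same carbon and the number does not move beyond the scatter. The other two steps, a 14-fold higher number from compound 1 to compound 2 (1.13 log units; beyond the scatter) and a 7.8-fold higher number from compound 1 to compound 3 (0.89 log units; beyond the scatter), both start from iodo, which plays no part in this change, so they bear on it only indirectly. For the measured compounds named here, no measured compound carries piperazin-1-yl, so the range has to stay wide. The expected change is small, a 1.6-fold lower number from compound 2 to compound 4 (0.20 log units; within the scatter), and no step beyond the scatter is anticipated. For compound 4 the estimated value is 18000 nM, with an expected range of 6000 nM to 50000 nM.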

Compound 4, half-maximal effective concentration: 1500 nM
The estimate for compound 4 lay 12-fold (1.08 log units) above the measured number, outside the stated range (below it).
By their numbers in this assay, from the lowest: compounds 4 and 1 (each within the scatter of the next); then compounds 3 and 2 (each within the scatter of the next).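

With a 19-fold lower number from compound 2 to compound 4 (1.28 log units; beyond the scatter) in this assay this para position proves able to carry a large change, so the earlier step from tert-butyl to pyrrolidin-1-yl does not hold for every ring joined through nitrogen. The two rings are themselves far apart, with an 11-fold lower number from compound 3 to compound 4 (1.04 log units; beyond the scatter) when piperazin-1-yl takes the place of pyrrolidin-1-yl, which shows that the identity of the ring matters here and not merely the presence of a ring amine; and a 1.4-fold lower number from compound 1 to compound 4 (0.15 log units; within the scatter) lies within the scatter, so piperazin-1-yl joins iodo at the low end of the series, although the two groups share little in the counts of atoms and rings. Nothing measured on these compounds bears on why piperazin-1-yl stands apart from pyrrolidin-1-yl.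

The compounds shown leave open which feature of piperazin-1-yl goes with the lower number, the ring size, the second nitrogen or the hydrogen on that nitrogen. Piperidin-1-yl, morpholin-4-yl and 4-methylpiperazin-1-yl on the same aromatic carbon would separate these features.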